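This account rests on a few compounds, and the source may have more. Where it says the series, first, only, none or still open, it means among the compounds named here.

Measured compounds:
Compound 1, `C/C(=N\NC(=O)c1cccc(S(=O)(=O)N2CCOCC2)c1)c1cccc(O)c1`: > 100000 nM in a functional assay on EC9706 cells (Homo sapiens) for antiproliferative activity, read by MTT assay, with a stated time of 72 h; on this read-out lower numbers stand for stronger inhibition and higher numbers for weaker inhibition
Compound 2, `C/C(=N\NC(=O)c1cccc(S(=O)(=O)N2CCOCC2)c1)c1cc(O)ccc1O`: 3510 nM
Compound 3, `C/C(=N\NC(=O)c1cccc(S(=O)(=O)N2CCOCC2)c1)c1cc(F)ccc1O`: 2210 nM

Compound 1 gives only a limit of the assay, not a number; that limit is the limit of > 100000 nM in this assay, at which 1 of the 3 values shown sits. Compound 3 has the lowest of the two real numbers, but its nearest neighbour, compound 2, sits close: a 1.6-fold lower number from compound 2 to compound 3 (0.20 log units; within the scatter). So compound 2 and compound 3 cannot be told apart on these data.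

The unmeasured compound 4 is `C/C(=N\NC(=O)c1cccc(S(=O)(=O)N2CCOCC2)c1)c1cccc(N)c1O`. It differs from compound 3 in one place: 3-amino-2-hydroxyphenyl in place of 5-fluoro-2-hydroxyphenyl on a carbon with a double bond to nitrogen. The hydroxy on the aromatic ring stays, so the change is a swap of fluoro for amino at a different position of that ring.

Among the measured compounds shown here, two measured steps bear on this. Where a hydroxy enters on an aromatic carbon, the step is an at least 28-fold lower number from compound 1 to compound 2 (1.45 log units; beyond the scatter), and where the 5-fluoro-2-hydroxyphenyl enters, the step is an at least 45-fold lower number from compound 1 to compound 3 (1.65 log units; beyond the scatter). For the measured compounds named here, the only step that changes a ring substituent while keeping the hydroxy is small: a 1.6-fold lower number from compound 2 to compound 3 (0.20 log units; within the scatter). By that step, the fluoro-to-amino swap is expected to produce no move beyond the scatter, so compound 4 is estimated at 2800 nM, with a range from 900 nM to 9000 nM. The expected step is a 1.3-fold higher number from compound 3 to compound 4 (0.10 log units; within the scatter).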

Compound 4, half-maximal inhibitory concentration: 3520 nM
Estimate against measurement, compound 4: 1.3-fold (0.10 log units) below, and the stated range covers the measured number.
By their numbers in this assay, from the lowest: compounds 3, 2 and 4 (each within the scatter of the next). At a limit, above all of these: compound 1.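

In this assay, the 3-amino-2-hydroxyphenyl group on the carbon with a double bond to nitrogen performs like the two earlier rings that carry a 2-hydroxy group, with a 1.6-fold higher number from compound 3 to compound 4 (0.20 log units; within the scatter) and a 1.0-fold higher number from compound 2 to compound 4 (0.00 log units; within the scatter), so compounds 2, 3 and 4 cannot be told apart. This ring therefore shows that the second ring substituent can be an amino as well as a fluoro or a hydroxy, and can sit at a different ring position, without a shift beyond the scatter, while the change from the 3-hydroxyphenyl group of compound 1 gives an at least 28-fold lower number from compound 1 to compound 4 (1.45 log units; beyond the scatter). That step is only a minimum, because compound 1 gives a limit and not a real number: the limit of > 100000 nM in this assay, at which 1 of the 4 values shown sits.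

Still open, as far as these compounds go, is what a plain phenyl or a 2-methoxyphenyl would do on the same carbon, a comparison that would test whether the 2-hydroxy group is needed at all. Also open, from the compounds shown here alone, is whether a dimethylamino group or a carboxylic acid in place of the amino would move the number beyond the scatter.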